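From Dimethylsulfamoyl to Sulfamoyl: Will Cells Tolerate Less?

The source may hold more compounds than are shown below. What is called first, only, known or untested is meant among the compounds shown, and "the series" means these compounds.

This story concerns three measured compounds that share a core and differ in the group attached through their amide, and one compound that has not yet been tested. They were examined in an ADME assay on LLC-MK2 cells (Macaca mulatta) for cytotoxicity, read by spectrophotometry and crystal violet staining, with a stated time of 4 days; a higher number here means that more compound is tolerated, a lower number that less compound is tolerated. Compound 1 `CC(C)n1ncc2c(C(=O)Nc3c(F)cccc3F)cc(-c3cccs3)nc21` gives > 200000 nM, which is a limit of the assay and not a number. Compound 3 `CC(C)n1ncc2c(C(=O)Nc3cccc(S(=O)(=O)N(C)C)c3)cc(-c3cccs3)nc21` gives > 200000 nM, also only a limit. Its standing is therefore simply (the limit of > 200000 nM in this assay, at which 2 of the 3 values shown sit).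

Compound 4 `CC(C)n1ncc2c(C(=O)Nc3cccc(S(N)(=O)=O)c3)cc(-c3cccs3)nc21` has amino in place of dimethylamino on a sulfonyl sulfur. The same difference can be read as dimethylsulfamoyl to sulfamoyl. Among the compounds with values here, the one measured compound with a sulfamoyl group is compound 2 `CC(C)n1ncc2c(C(=O)Nc3ccc(F)c(S(N)(=O)=O)c3)cc(-c3cccs3)nc21`, and in this assay compound 2 gives a true number, 50000 nM. On that basis, the expected change is an at least 2.5-fold lower number from compound 3 to compound 4 (0.39 log units; beyond the scatter), a move towards less compound being tolerated and probably beyond the scatter. The assay could, however, again report only a limit. Compound 4 is estimated at 80000 nM, with an expected range from 30000 nM to 200000 nM.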

Compound 4, half-maximal cytotoxic concentration: 25000 nM
Beside the measured number, compound 4's estimate is 3.2-fold (0.51 log units) above it; measured number outside the range, below it.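

In this assay, amino in place of dimethylamino on the sulfonyl sulfur gives an at least 8.0-fold lower number from compound 3 to compound 4 (0.90 log units; beyond the scatter), so this change is now seen directly and not only inferred from a related compound. Hydrogen in place of fluoro on an aromatic carbon gives a 2.0-fold lower number from compound 2 to compound 4 (0.30 log units; within the scatter), so the two sulfamoyl compounds cannot be told apart. With 3-sulfamoylphenyl in place of 2,6-difluorophenyl on an amide-type nitrogen, the result is an at least 8.0-fold lower number from compound 1 to compound 4 (0.90 log units; beyond the scatter), and this step and the one from compound 3 are open-ended because compound 1 and compound 3 each stand only at a limit of the assay: the limit of > 200000 nM in this assay, at which 2 of the 4 values shown sit.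

Going by these compounds, the true size of the step from compound 3 therefore remains open. Also open, on these data alone, is where methylamino on the sulfonyl sulfur would fall relative to amino and dimethylamino.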